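Piperidine carbonyl for oxane carbonyl on the core amine

The source may hold more compounds than are shown below. What is called first, only, known or untested is meant among the compounds shown, and "the series" means these compounds.

Compound 2 `O=C(C1CCCCO1)N1CCc2nc(C#Cc3ccccc3)sc2C1` carries a (oxan-2-yl)carbonyl on the ring amine of the shared core. Among the measured compounds shown here, in an assay on HEK293 cells for positive allosteric modulation of metabotropic glutamate receptor 5 (Homo sapiens), read by FLIPR, with a stated time of 1 h (a lower number here means that less compound is needed, a higher number that more compound is needed for the effect), compound 2 gives 320 nM, the highest of the two numbers measured so far. Compound 1 `CCCCN1CCc2nc(C#Cc3ccccc3)sc2C1`, with butyl on the same nitrogen, gives 110 nM; the step of a 2.9-fold higher number from compound 1 to compound 2 (0.46 log units; beyond the scatter) exchanges the alkyl chain for the carbonyl-linked ring. Compound 3 `O=C(N1CCCCC1)N1CCc2nc(C#Cc3ccccc3)sc2C1` keeps the carbonyl and changes only the ring attached to it: piperidin-1-yl in place of oxan-2-yl on a carbonyl carbon. For the measured compounds named here, no measured step bears directly on this exchange: the single step available replaces butyl with (oxan-2-yl)carbonyl and does not separate what the ring contributes from what the carbonyl contributes. Both rings are six-membered and non-aromatic with a single hetero atom, so the change is a small one at the periphery of the molecule. With nothing in the measured pairs to anchor a direction, the expected step of no change at the digits printed from compound 2 to compound 3 (within the scatter) is one within the usual scatter, with no direction favoured. Compound 3 is therefore estimated at 320 nM in this assay, with a range of 110 nM to 950 nM.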

Compound 3, half-maximal effective concentration: 75 nM
The estimate for compound 3 lay 4.3-fold (0.63 log units) above the measured number, outside the stated range (below it).
By their numbers in this assay, from the lowest: compounds 3 and 1 (each within the scatter of the next); then compound 2.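

On the carbonyl carbon whose other neighbour is the amide-type nitrogen in a ring, the identity of the ring matters in this assay: the step of a 4.3-fold lower number from compound 2 to compound 3 (0.63 log units; beyond the scatter) exchanges oxan-2-yl for piperidin-1-yl with the heavy-atom count unchanged, so this exchange is not a silent one at the periphery. The carbonyl link as such is no longer implicated, since the step of a 1.5-fold lower number from compound 1 to compound 3 (0.17 log units; within the scatter) stays within the scatter; the higher number of compound 2 relative to compound 1 therefore goes with the (oxan-2-yl)carbonyl group and not with every carbonyl-linked ring. No measurement at hand accounts for this difference in the two rings.

The two rings differ at once in their hetero atom and in the atom that joins them to the carbonyl carbon, so the compounds shown do not tell which of these changes goes with the lower number. Cyclohexyl, attached through carbon and carrying no hetero atom, and morpholin-4-yl, attached through nitrogen and carrying a ring oxygen as well, would pull these two apart on the same carbonyl carbon.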